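From Ethoxy to Propoxy in a Growth Inhibition Series

The source may hold more compounds than are shown below. What is called first, only, known or untested is meant among the compounds shown, and "the series" means these compounds.

Compound 1 `CCCOC(=O)N1N=C(c2ccccc2)CC1c1cc(OC)c(OC)c(OC)c1`: > 10000 nM (a limit of the assay)
Compound 2 `CCOC(=O)N1N=C(c2cccc(OC)c2)CC1c1cc(OC)c(OC)c(OC)c1`: 5820 nM

Among the measured compounds shown here, in a functional assay on HepG2 cells (Homo sapiens) for antiproliferative activity, read by MTT assay, with a stated time of 48 h (on this read-out lower numbers stand for stronger inhibition of growth and higher numbers for weaker inhibition of growth), compound 2 gives 5820 nM, the only actual number so far. The entry for compound 1, > 10000 nM, is a limit and not a number.

Compound 3 `CCCOC(=O)N1N=C(c2cccc(OC)c2)CC1c1cc(OC)c(OC)c(OC)c1` differs from compound 2 in one place, where ethoxy becomes propoxy: methyl in place of hydrogen on a saturated chain carbon, two bonds along the chain from an oxygen next to a carbonyl group. For the measured compounds named here, no measured pair shows this change on its own, so there is no direct precedent for its size. In this assay, a small shift toward weaker inhibition of growth is expected, possibly no larger than the scatter. This expectation starts from compound 2 at 5820 nM. The expected change is a 1.3-fold higher number from compound 2 to compound 3 (0.11 log units; within the scatter). For compound 3, the estimated value is 7500 nM, with an expected range of 3000 nM to 18000 nM.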

Compound 3, concentration for 50% growth inhibition: > 10000 nM
Compound 3: a limit, no number; the forecaster's own chance of this, stated with the estimate: 35%; middle value at least 1.3-fold (0.12 log units) away from the limit.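

In this assay, among the compounds shown here, the change from ethoxy to propoxy can now be read directly for the first time, as an at least 1.7-fold higher number from compound 2 to compound 3 (0.23 log units; that floor lies within the scatter). The entry for compound 3 is a limit and not a number, so this step has a floor but no measured size, and it does not settle how far the extra methyl moves the read-out. With propoxy, the one compound that gave a number in this series also passes to the edge of the assay's range: the limit of > 10000 nM in this assay, at which 2 of the 3 values shown sit.

As far as these compounds go, the step between compound 1 and compound 3, methoxy in place of hydrogen on an aromatic carbon, cannot be read, so the effect of that group alongside propoxy stays open. Also open, from the compounds shown here alone, is how a butoxy group or an amine in place of the propoxy would read.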